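A few compounds are considered here, and "the series" means these few. Any claim that something is new, unique, unknown or untested is made for them only; others in the source may bear on it.

Compound 2, `C[C@H](NC(=O)c1cc(C(F)(F)F)nn1C)c1nc(-c2cccc(F)c2)no1`, gives 136 nM in an assay on T-REx-293 cells for inhibition of potassium channel subfamily T member 1 (Homo sapiens), read by patch clamp (a higher number here means a weaker inhibitor, a lower number a stronger inhibitor), the lowest number among the three compounds measured there. Compound 1, `Cc1cccc(-c2noc(C(C)NC(=O)c3cc(C4CC4)nn3C)n2)c1`, gives 1880 nM in this assay, and compound 3, `C[C@@H](c1nc(-c2cccc(F)c2)no1)N(C)C(=O)c1cc(C(F)(F)F)nn1C`, gives 6490 nM. For the measured compounds named here, the single measured step, a 48-fold higher number from compound 2 to compound 3 (1.68 log units; beyond the scatter), is large and concerns the amide nitrogen only. Going by the values given here, compound 1 and compound 2 differ in more than one place, so their two values show only that compound 1 lies well above compound 2.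

Compound 4, `Cc1cccc(-c2noc([C@H](C)NC(=O)c3cc(C(F)(F)F)nn3C)n2)n1`, carries 6-methylpyridin-2-yl in place of 3-fluorophenyl on an aromatic carbon. Among the compounds with values here, no measured step touches the aromatic ring on that carbon: the change from compound 2 to compound 3 sits elsewhere, and compound 1 differs from compound 2 in two places at once. There is therefore nothing in these numbers that would point to a step beyond the scatter in either direction, and a value close to that of compound 2, with wide uncertainty, is what is expected. The estimated step, a 1.8-fold higher number from compound 2 to compound 4 (0.26 log units; within the scatter), reflects that caution. Compound 4 is thus expected to give about 250 nM in this assay, with a range from 70 nM to 900 nM.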

Compound 4, half-maximal inhibitory concentration: > 30000 nM
Compound 4 ended at the assay's limit; the forecaster's own chance of this, stated with the estimate: 3%; at least 120-fold (2.07 log units) between middle value and limit.
By their numbers in this assay, from the lowest: compound 2; then compound 1; then compound 3. At a limit, above all of these: compound 4.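

The position on the five-membered aromatic ring, between two ring nitrogen atoms, had not been touched by any single-place step, and it now proves at least as demanding as the amide nitrogen in this assay: besides a 48-fold higher number from compound 2 to compound 3 (1.68 log units; beyond the scatter), there is now an at least 220-fold higher number from compound 2 to compound 4 (2.34 log units; beyond the scatter), from 6-methylpyridin-2-yl in place of 3-fluorophenyl. Compound 4 stands at a limit of this assay, not at a number: the limit of > 30000 nM in this assay, at which 1 of the 4 values shown sits. The two groups have the same count of heavy atoms and each is a six-membered aromatic ring, so a change that leaves these counts as they are can still cost this much, with the entering group differing in its ring nitrogen, its hydrogen-bond acceptor and its methyl, and in having no fluorine.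

These differences arrive together in one step, so the compounds shown cannot assign the loss to any one of them; a plain phenyl or a pyridin-2-yl without the methyl would be needed to separate them. Going by these compounds, whether a saturated ring such as morpholine on this carbon would fare any better also remains open.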